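From Ethyl to Cyclohexyl on a Fused Triazole Core

The source may report more compounds than this note shows. Statements on the series, on what has been measured and on what is new or still open speak of the compounds shown alone.

Compound 1 `COc1ccc(-c2nnc3nnc(N4CCCCC4)n3n2)cc1`: > 100000 nM
Compound 2 `CC(C)c1nnc2nnc(N3CCCC3)nn12`: 46800 nM
Compound 3 `CCc1nnc2nnc(N3CCCC3)nn12`: 47000 nM

In a functional assay on MCF7 cells (Homo sapiens) for cytotoxicity, read by MTT assay, with a stated time of 72 h (on this read-out higher numbers stand for weaker inhibition and lower numbers for stronger inhibition), compound 1 gives only a limit of the assay, > 100000 nM, not a number (the limit of > 100000 nM in this assay, at which 1 of the 3 values shown sits). Compound 2 gives 46800 nM and compound 3 gives 47000 nM in this assay; the step of a 1.0-fold higher number from compound 2 to compound 3 (0.00 log units; within the scatter) is within the scatter, so compound 3 sits beside compound 2 with no real gap between them.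

Compound 4 `C1CCC(c2nnc3nnc(N4CCCC4)nn23)CC1` differs from compound 3 by cyclohexyl in place of ethyl on an aromatic carbon. For the measured compounds named here, the only measured step at this position, swapping a small saturated group for a smaller one, moved nothing beyond the scatter. Compound 4 is therefore expected to show a step of a 1.2-fold lower number from compound 3 to compound 4 (0.07 log units; within the scatter), with no change beyond the scatter. Compound 4 is estimated at 40000 nM in this assay, within 15000 nM to 100000 nM.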

Compound 4, half-maximal inhibitory concentration: 37700 nM
For compound 4 the middle estimate is 1.1-fold (0.03 log units) above the measured one, within the range that was stated.
By their numbers in this assay, from the lowest: compounds 4, 2 and 3 (each within the scatter of the next). At a limit, above all of these: compound 1.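

The earlier compounds shown here compared only ethyl and isopropyl, so they covered just a small change in a saturated group on this aromatic carbon. In this assay, even a six-membered non-aromatic ring of carbon leaves the value within the scatter, with a 1.2-fold lower number from compound 3 to compound 4 (0.10 log units; within the scatter) and a 1.2-fold lower number from compound 2 to compound 4 (0.09 log units; within the scatter), so these three saturated groups cannot be told apart here. Nothing given here explains this lack of change. Still open, as far as these compounds go, is whether a group carrying an amine or a carboxylic acid at this position would shift the value beyond the scatter.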